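Swapping the aryl group on compound 3

This account rests on a few compounds, and the source may have more. Where it says the series, first, only, none or still open, it means among the compounds named here.

Of the compounds shown here, three sharing one core have been measured in a functional assay on PC-3 cells (Homo sapiens) for cytotoxicity, read by MTT assay, with a stated time of 72 h; on this read-out lower numbers stand for stronger inhibition and higher numbers for weaker inhibition. Compound 1 (`O=C(/C=C/c1cc(Br)c(O)c(Br)c1)Nc1cc2c(Nc3ccc(F)c(Cl)c3)ncnc2cc1O[C@H]1CCOC1`) gives 25500 nM in this test, compound 2 (`COc1ccc(/C=C/C(=O)Nc2cc3c(Nc4ccc(F)c(Cl)c4)ncnc3cc2O[C@H]2CCOC2)c(OC)c1OC`) gives 7670 nM and compound 3 (`COc1cc(/C=C/C(=O)Nc2cc3c(Nc4ccc(F)c(Cl)c4)ncnc3cc2O[C@H]2CCOC2)cc(OC)c1`) gives 25600 nM on the same scale. Compound 3 therefore stands level with compound 1, and both sit above compound 2.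

Compound 4 (`O=C(/C=C/c1ccc(F)cc1Cl)Nc1cc2c(Nc3ccc(F)c(Cl)c3)ncnc2cc1O[C@H]1CCOC1`) carries 2-chloro-4-fluorophenyl in place of 3,5-dimethoxyphenyl on a double-bonded chain carbon bound to a double-bonded chain carbon. The measured steps that bear on this change alter the same group. One is a 1.0-fold higher number from compound 1 to compound 3 (0.00 log units; within the scatter) and the other is a 3.3-fold higher number from compound 2 to compound 3 (0.52 log units; beyond the scatter) at most a modest shift. Going by the values given here, none of the measured compounds carries the entering group, so the data fix no direction. A small step towards a lower number is expected, probably within the scatter. The estimated change is a 1.6-fold lower number from compound 3 to compound 4 (0.20 log units; within the scatter) in this assay for this replacement. Compound 4 is estimated at 16000 nM with an expected range of 6000 nM to 40000 nM for the coming measurement.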

Compound 4, half-maximal inhibitory concentration: 7150 nM
The estimate for compound 4 lay 2.2-fold (0.35 log units) above the measured number, and the stated range covers the measured number.
By their numbers in this assay, from the lowest: compounds 4 and 2 (each within the scatter of the next); then compounds 1 and 3 (each within the scatter of the next).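

In this assay, putting 2-chloro-4-fluorophenyl in place of 3,5-dimethoxyphenyl gives a 3.6-fold lower number from compound 3 to compound 4 (0.55 log units; beyond the scatter), so an aryl group with no oxygen atom reaches the lower level at this position, a level previously held only by the 2,3,4-trimethoxyphenyl group of compound 2. The step of a 1.1-fold lower number from compound 2 to compound 4 (0.03 log units; within the scatter) lies within the scatter, which places the two groups level, so methoxy groups are not required for that level. Halogens alone do not guarantee it either: the step of a 3.6-fold lower number from compound 1 to compound 4 (0.55 log units; beyond the scatter) leaves the 3,5-dibromo-4-hydroxyphenyl group of compound 1 at the higher level, against any simple halogen pattern. No measurement in hand accounts for these differences.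

On these data alone, whether the chlorine or the fluorine of compound 4 matters more remains open. So does how a plain phenyl, a 4-chlorophenyl, a 4-fluorophenyl or a 4-aminophenyl group would read at this position.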